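The compounds below may be only part of what the source reports. "The series", "measured", "known", "first", "only" and "open" are said of these compounds alone.

The measured compounds:
Compound 1, `O=S(=O)(NCCCNCc1ccc(Cl)c(Cl)c1)c1cc(C(F)(F)F)cc(C(F)(F)F)c1`: in a functional assay on HT-29 cells (Homo sapiens) for inhibition, read by MTT assay, with a stated time of 72 h (a lower number here means a stronger inhibitor of growth, a higher number a weaker inhibitor of growth), compound 1 gives 4700 nM.
Compound 2, `CN(CCCNS(=O)(=O)c1cc(C(F)(F)F)cc(C(F)(F)F)c1)Cc1ccccc1`: in this assay compound 2 reaches only a limit of the assay, > 50000 nM.

Compound 2 stands at the weak end of what has been seen: its value is a limit, not a number, and it sits at the limit of > 50000 nM in this assay, at which 1 of the 2 values shown sits. Going by the values given here, the one measured step that leads to it, an at least 10-fold higher number from compound 1 to compound 2 (1.02 log units; beyond the scatter), shows that putting benzyl(methyl)amino in place of (3,4-dichlorobenzyl)amino costs heavily. Compound 3, `O=S(=O)(NCCCNCc1ccc(Br)cc1)c1cc(C(F)(F)F)cc(C(F)(F)F)c1`, is not yet measured. It differs from compound 2 by (4-bromobenzyl)amino in place of benzyl(methyl)amino on a saturated chain carbon, three bonds along the chain from a sulfonamide nitrogen. This change largely reverses the measured step, bringing in a (4-bromobenzyl)amino group closer in kind to the (3,4-dichlorobenzyl)amino group of compound 1. The step from compound 1 to compound 2 therefore bears on it, and its size suggests a move back toward the value of compound 1, though compound 3 carries one bromine where compound 1 carries two chlorines, so a full return is not assumed. Compound 3 is expected at 9000 nM in this assay, within 3000 nM to 40000 nM. The expected step, an at least 5.5-fold lower number from compound 2 to compound 3 (0.74 log units; beyond the scatter), is estimated as a gain beyond the scatter, read from a limit.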

Compound 3, concentration for 50% growth inhibition: 2200 nM
For compound 3 the middle estimate is 4.1-fold (0.61 log units) above the measured one; measured number below the stated range.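

In this assay, the step of an at least 22-fold lower number from compound 2 to compound 3 (1.35 log units; beyond the scatter) shows that activity can return in this series with a benzylamine side chain, and that the earlier loss is not permanent for this part of the molecule. Going by these compounds alone, compound 2 remains a limit of the assay, not a number, so this step has only a lower bound on its size: the limit of > 50000 nM in this assay, at which 1 of the 3 values shown sits. The step of a 2.1-fold lower number from compound 1 to compound 3 (0.33 log units; beyond the scatter) is the first comparison with the amine hydrogen kept in place, and it shows that 4-bromophenyl serves at least as well as 3,4-dichlorophenyl on a saturated chain carbon bound to an amine nitrogen, although the gain is modest.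

Both steps that involve compound 2 change the nitrogen substituent and the ring halogens together, so the shares of the two changes stay unresolved; a plain benzylamino group and a (4-bromobenzyl)(methyl)amino group would separate them. Also open, going by these compounds, is whether the trend extends to other ring substituents, such as a 4-chlorobenzyl or 4-methoxybenzyl group, or holds with a longer chain between the sulfonamide nitrogen and the amine.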